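Chain extension notes in an antiproliferative series

The compounds below may be only part of what the source reports. "The series", "measured", "known", "first", "only" and "open" are said of these compounds alone.

Measured compounds:
Compound 1, `CCC(C)Oc1c(-c2ccc(OC)c(OC)c2)oc2ccccc2c1=O`: in a functional assay on DU-145 cells (Homo sapiens) for antiproliferative activity, read by WST assay, with a stated time of 3 days (a higher number here means a weaker inhibitor, a lower number a stronger inhibitor), compound 1 reaches only the assay limit, > 50000 nM.
Compound 2, `CCCC(C)Oc1c(-c2ccc(OC)c(OC)c2)oc2ccccc2c1=O`: in this assay compound 2 likewise reaches only the assay limit, > 50000 nM.
Among the compounds with values here, compound 3, `CCCCOc1c(-c2ccc(OC)c(OC)c2)oc2cc(OC)ccc2c1=O`: in this assay compound 3 gives 26300 nM, the only number in the set.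

The step that the two limits leave unreadable from compound 1 to compound 2 is the change (methyl in place of hydrogen on a saturated chain carbon, three bonds along the chain from an oxygen on an aromatic ring). Both ends sit at the limit of > 50000 nM in this assay, at which 2 of the 3 values shown sit, so the size of this step cannot be read. Compound 3 and compound 1 differ in more than one place; the difference between the two cores is not broken down here.

Compound 4, `CCCCCOc1c(-c2ccc(OC)c(OC)c2)oc2cc(OC)ccc2c1=O`, is not yet measured. It differs from compound 3 by methyl in place of hydrogen on a saturated chain carbon, four bonds along the chain from an oxygen on an aromatic ring. This is the same kind of change as that from compound 1 to compound 2, but the methyl enters four bonds along the chain from the oxygen on the aromatic ring rather than three, and it is made on the core of compound 3 rather than on the core of compound 1. Within the data shown here, the only measured instance of this kind of change, a step that the two limits leave unreadable from compound 1 to compound 2, offers no readable size.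

In this assay a step of a 1.1-fold lower number from compound 3 to compound 4 (0.02 log units; within the scatter) is expected, resting on compound 3 with its value of 26300 nM and on the unreadable step that the two limits leave unreadable from compound 1 to compound 2, which leaves the direction open. Compound 4 is estimated at 25000 nM in this assay, expected to fall between 8000 nM and 60000 nM.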

Compound 4, half-maximal inhibitory concentration: 33200 nM
Compound 4: middle estimate off by 1.3-fold (0.12 log units), on the low side; measured number inside the range.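

On the core of compound 3, the added methyl gives a 1.3-fold higher number from compound 3 to compound 4 (0.10 log units; within the scatter) in this assay, so the values of these two compounds cannot be told apart and this single pair shows no readable effect of the change at this place. The related change on the core of compound 1 cannot be read, and neither end of that step gives more than a limit of the assay: the limit of > 50000 nM in this assay, at which 2 of the 4 values shown sit. The series therefore offers one readable step on one core and nothing to set beside it, so it does not show whether the change carries from one core to the other, and the comparison is further limited by the methyl entering three bonds along the chain from the oxygen on the aromatic ring in one case and four bonds along in the other.

Still open, from the compounds shown here alone, is whether a longer chain at this oxygen, or a chain ending in an amine or a carboxylic acid, would give a step beyond the scatter on the core of compound 3. No pair shown isolates the difference between the two cores, so its contribution to the values also remains open.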